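Dimethylamino for methyl on two cores of the series

A few compounds are considered here, and "the series" means these few. Any claim that something is new, unique, unknown or untested is made for them only; others in the source may bear on it.

Compound 1 `Cc1ccc(/C=C2\S/C(=N\c3csc(-c4ccc(Cl)cc4)c3)NC2=O)cc1` and compound 2 `CN(C)c1ccc(/C=C2\S/C(=N\c3csc(-c4ccc(Cl)cc4)c3)NC2=O)cc1` share one core; compound 3 `Cc1ccc(N2C(=O)CS/C2=N\c2csc(-c3ccc(Cl)cc3)c2)cc1` and compound 4 `CN(C)c1ccc(N2C(=O)CS/C2=N\c2csc(-c3ccc(Cl)cc3)c2)cc1` share another, and the difference between the two cores is not broken down here. In a functional assay on MCF7 cells (Homo sapiens) for cytotoxicity, read by MTT assay, with a stated time of 72 h (on this read-out higher numbers stand for weaker inhibition and lower numbers for stronger inhibition), compound 1 gives 900 nM and compound 2 gives 400 nM. The change dimethylamino in place of methyl on an aromatic carbon gave a 2.3-fold lower number from compound 1 to compound 2 (0.35 log units; beyond the scatter). For compound 3 the result in this assay is a limit of the assay, > 50000 nM. Compound 4 carries the same change on the second core, (dimethylamino in place of methyl on an aromatic carbon). Because compound 3 sits at the limit of > 50000 nM in this assay, at which 1 of the 3 values shown sits, a step of the size seen from compound 1 to compound 2 is not expected to bring compound 4 into the range where a number is read. The step expected here is an at least 1.2-fold lower number from compound 3 to compound 4 (0.09 log units; that floor lies within the scatter). Compound 4 is estimated at 40000 nM, with a range from 10000 nM to 200000 nM, and most probably reported as a limit again.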

Compound 4, half-maximal inhibitory concentration: > 50000 nM
Compound 4: only a limit was reported; the forecaster's own chance of this, stated with the estimate: 75%; at least 1.2-fold (0.09 log units) between middle value and limit.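

The step from compound 3 to compound 4 cannot be read, as both compounds are reported only at the same limit: the limit of > 50000 nM in this assay, at which 2 of the 4 values shown sit.

Going by these compounds, whether dimethylamino in place of methyl on the core of compound 3 shifts the read-out at all remains open.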